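A few compounds are considered here, and "the series" means these few. Any claim that something is new, unique, unknown or untested is made for them only; others in the source may bear on it.

Among the measured compounds shown here, compound 1, `Nc1nc2cc(-c3nn(CCCC(=O)NO)c4ncnc(N)c34)ccc2o1`, is the first of three hydroxamic acids examined in a functional assay on HCT-116 cells (Homo sapiens) for inhibition, read by MTT assay, with a stated time of 72 h; a lower number here means a stronger inhibitor, a higher number a weaker inhibitor. In this assay compound 1 gives 19600 nM, the lowest of the two numbers shown. Compound 2, `Nc1ncnc2c1c(-c1cnc3[nH]ccc3c1)nn2CCCCCC(=O)NO`, gives 63700 nM in this assay, and the gap between compound 1 and compound 2 lies beyond the usual scatter. Compound 3, `Nc1ncnc2c1c(-c1cnc3[nH]ccc3c1)nn2CCCC(=O)NO`, reaches only a limit of this assay, > 150000 nM. For the measured compounds named here, the one measured step that changes the chain alone is an at least 2.3-fold higher number from compound 2 to compound 3 (0.37 log units; beyond the scatter), where a shorter chain brought a weaker inhibitor, as far as the limit of > 150000 nM in this assay, at which 1 of the 3 values shown sits, allows to say.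

Compound 4, `Nc1nc2cc(-c3nn(CCCCCCC(=O)NO)c4ncnc(N)c34)ccc2o1`, differs from compound 1 by 3-(hydroxycarbamoyl)propyl in place of hydroxycarbamoyl on a saturated chain carbon, three bonds along the chain from an aromatic nitrogen. This runs opposite to the measured step: the chain grows longer rather than shorter. On that basis a modest move toward a lower number in this assay is expected, an estimated step of a 2.5-fold lower number from compound 1 to compound 4 (0.39 log units; beyond the scatter). Compound 4 is therefore expected to give about 8000 nM in this assay, plausibly between 2500 nM and 25000 nM.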

Compound 4, half-maximal inhibitory concentration: 5390 nM
Beside the measured number, compound 4's estimate is 1.5-fold (0.17 log units) above it; the range from low to high includes it.
By their numbers in this assay, from the lowest: compound 4; then compound 1; then compound 2. At a limit, above all of these: compound 3.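

In this assay, lengthening the chain from 3-(hydroxycarbamoyl)propyl to 6-(hydroxycarbamoyl)hexyl gives a 3.6-fold lower number from compound 1 to compound 4 (0.56 log units; beyond the scatter), so a longer chain now goes with a lower number on the core of compound 1 as well as on the core shared by compound 2 and compound 3. Among the compounds shown here, neither pair goes against this, although each core offers only one comparison. The new step also joins two true measurements, so its full size can be read, whereas the earlier chain step ended at a limit rather than a number: the limit of > 150000 nM in this assay, at which 1 of the 4 values shown sits.

The compounds shown leave open whether a chain longer than 6-(hydroxycarbamoyl)hexyl would lower the number further or reverse the trend. They also leave open what a carboxylic acid in place of the hydroxycarbamoyl group would give on the same chain.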